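The compounds below may be only part of what the source reports. "The series", "measured", "known", "first", "only" and "open" are said of these compounds alone.

Of the compounds shown here, three have been measured in a functional assay on HCT-116 cells (Homo sapiens) for inhibition, read by MTT assay, with a stated time of 48 h; a higher number here means a weaker inhibitor, a lower number a stronger inhibitor. Compound 1, `C/C=C/C(=O)N(Cc1ccc(OC)c(C)c1)c1cc(OC)c(OC)c(OC)c1`, gives 23500 nM in this assay. Compound 2, `COc1ccc(CNc2cc(OC)c(OC)c(OC)c2)cc1[N+](=O)[O-]`, gives 18200 nM in this assay, a number that sits within the usual scatter of the value for compound 1, so the two cannot be told apart. Compound 3, `COc1cc(NCc2ccccc2)cc(OC)c1OC`, reaches only the limit of this assay, > 80000 nM, and therefore has no number of its own; this is the case noted as the limit of > 80000 nM in this assay, at which 1 of the 3 values shown sits. Among the two numbers that are real numbers, compound 1 holds the higher one, with compound 2 the nearest.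

The next compound, compound 4, `C/C=C/C(=O)N(Cc1ccc(OC)c(O)c1)c1cc(OC)c(OC)c(OC)c1`, differs from compound 1 in one place: hydroxy in place of methyl on an aromatic carbon. The change sits on an aromatic carbon of a six-membered aromatic ring of carbon only, and read one bond further out it turns a 4-methoxy-3-methylphenyl into a 3-hydroxy-4-methoxyphenyl. Among the measured compounds shown here, no pair of measured compounds shows this change, so nothing here says how large its effect should be. The step expected here reads a 1.3-fold lower number from compound 1 to compound 4 (0.12 log units; within the scatter), small enough to fall within the usual scatter. For compound 4 in this assay the estimate is 18000 nM, with a plausible range from 6000 nM to 55000 nM.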

Compound 4, half-maximal inhibitory concentration: 55 nM
Compound 4: the middle estimate sits 330-fold (2.51 log units) above what was measured, outside the stated range (below it).
By their numbers in this assay, from the lowest: compound 4; then compounds 2 and 1 (each within the scatter of the next). At a limit, above all of these: compound 3.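

In this assay, exchanging a single heavy atom, the methyl for a hydroxy on this aromatic carbon ortho to a methoxy group, gives a 430-fold lower number from compound 1 to compound 4 (2.63 log units; beyond the scatter) and so shows that this one position can change the reading very strongly, which is something compounds 1, 2 and 3 could not reveal since no two of them differ in one place only. The change turns 4-methoxy-3-methylphenyl into 3-hydroxy-4-methoxyphenyl and adds one hydrogen-bond donor and one hydrogen-bond acceptor by count, while the rest of the structure of compound 1 stays the same, so the whole step belongs to this one swap. Nothing measured here explains why the step is so large.

On these data alone, it remains open whether an amino group or a fluorine on this same carbon would give a number close to that of compound 4 or close to that of compound 1, and so whether the hydroxy itself is needed. As far as these compounds go, it also remains open whether the same swap would have a step of similar size on the core of compound 2.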